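One more aryl swap on a shared core

The compounds below may be only part of what the source reports. "The series", "measured", "known", "first", "only" and "open" are said of these compounds alone.

Measured so far in a functional assay on MCF7 cells (Homo sapiens) for inhibition, read by MTT assay, with a stated time of 72 h; a higher number here means a weaker inhibitor, a lower number a stronger inhibitor:
- compound 1 `COc1cc2c(Oc3ccc(NC(=O)c4nn(-c5ccccc5)cc(C)c4=O)cc3)ccnc2cc1OCCCCCCC(=O)NO` gives 1610 nM
- compound 2 `COc1cc2c(Oc3ccc(NC(=O)c4nn(-c5ccc(F)c(Cl)c5)cc(C)c4=O)cc3)ccnc2cc1OCCCCCCC(=O)NO` gives 2200 nM
- compound 3 `COc1cc2c(Oc3ccc(NC(=O)c4nn(-c5ccc(C)cc5C)cc(C)c4=O)cc3)ccnc2cc1OCCCCCCC(=O)NO` gives 2430 nM

Compound 3 stands level with the other two compounds, as its gaps to them show (a 1.5-fold higher number from compound 1 to compound 3 (0.18 log units; within the scatter); a 1.1-fold higher number from compound 2 to compound 3 (0.04 log units; within the scatter)). Compound 4 `COc1cc2c(Oc3ccc(NC(=O)c4nn(-c5cccc(C(F)(F)F)c5)cc(C)c4=O)cc3)ccnc2cc1OCCCCCCC(=O)NO` has not yet been measured. It carries 3-(trifluoromethyl)phenyl in place of 2,4-dimethylphenyl on an aromatic nitrogen.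

All three measured steps change the group at this same place, so they are the best guide. The remaining one, between the first two compounds, is just as small (a 1.4-fold higher number from compound 1 to compound 2 (0.14 log units; within the scatter)). Three different groups have therefore given values within the scatter of one another, although three compounds are a thin basis and the new group has not been tried here. No step beyond the scatter is expected in this assay, and these values point to no clear direction. The estimate simply takes the common level of the three compounds. The expected step is small (a 1.2-fold lower number from compound 3 to compound 4 (0.07 log units; within the scatter)). For compound 4 the estimated value is 2050 nM, with an expected range from 1150 nM to 3600 nM (an estimate, not a measurement).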

Compound 4, half-maximal inhibitory concentration: 750 nM
The estimate for compound 4 lay 2.7-fold (0.44 log units) above the measured number, and the stated range ends above it.
By their numbers in this assay, from the lowest: compound 4; then compounds 1, 2 and 3 (each within the scatter of the next).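

In this assay, going by these compounds alone, the aryl group on the aromatic nitrogen had so far seemed not to matter, but 3-(trifluoromethyl)phenyl separates from all three earlier groups, with a 3.2-fold lower number from compound 3 to compound 4 (0.51 log units; beyond the scatter) against 2,4-dimethylphenyl, a 2.9-fold lower number from compound 2 to compound 4 (0.47 log units; beyond the scatter) against 3-chloro-4-fluorophenyl and a 2.1-fold lower number from compound 1 to compound 4 (0.33 log units; beyond the scatter) against unsubstituted phenyl. The last step is the simplest to read, since a single trifluoromethyl replaces a hydrogen on an aromatic carbon, so this position can respond to a change on the ring, although compound 2 and compound 3 show that not every substituted ring moves the number beyond the scatter of compound 1. Nothing in the data shown explains why this group stands apart.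

On these data alone, whether the lower number belongs to the trifluoromethyl group itself remains open, since a nitrile or a methoxy group at that ring position would be needed to test it. The steps are also modest, and a cell-based read-out like this one cannot alone say which process inside the cells changed.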